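Thiophen-3-yl for furan-3-yl: notes on the series

A few compounds are considered here, and "the series" means these few. Any claim that something is new, unique, unknown or untested is made for them only; others in the source may bear on it.

In a functional assay on A549 cells (Homo sapiens), read by MTT assay, with a stated time of 72 h (on this read-out lower numbers stand for stronger inhibition and higher numbers for weaker inhibition), compound 3 (`CSc1ncnc2c1c(-c1ccoc1)cn2[C@@H]1O[C@H](CO)[C@@H](O)[C@H]1O`) gives the lowest number shown (280 nM). Compound 2 (`C#Cc1cn([C@@H]2O[C@H](CO)[C@@H](O)[C@H]2O)c2ncnc(OC)c12`) gives 8160 nM. Compound 1 (`COc1ncnc2c1c(-c1ccccc1)cn2[C@@H]1O[C@H](CO)[C@@H](O)[C@H]1O`) reaches only a limit of the assay (> 20000 nM).

The next compound is compound 4 (`CSc1ncnc2c1c(-c1ccsc1)cn2[C@@H]1O[C@H](CO)[C@@H](O)[C@H]1O`), with thiophen-3-yl in place of furan-3-yl on an aromatic carbon. For the measured compounds named here, only one measured step touches this carbon, with ethynyl in place of phenyl: an at least 2.4-fold lower number from compound 1 to compound 2 (0.38 log units; beyond the scatter) in this assay on that swap. It gives only weak guidance, since it replaces one kind of group with a very different one and starts from a limit. Compound 1 and compound 2 also differ from compound 3 in a second place. The swap to compound 4 keeps the counted features the same, so no shift beyond the scatter is expected, and no direction is favoured.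

The estimated step is a 1.1-fold lower number from compound 3 to compound 4 (0.05 log units; within the scatter) in this assay for now. Compound 4 is expected near 250 nM with an estimated range from 80 nM to 800 nM in this reading.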

Compound 4, half-maximal inhibitory concentration: > 20000 nM
Compound 4 gave a limit, no number (the forecaster's own chance of this, stated with the estimate: 3%); at least 80-fold (1.90 log units) between middle value and limit.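

In this assay this aromatic carbon separates two groups that match in every counted feature: the swap gives an at least 71-fold higher number from compound 3 to compound 4 (1.85 log units; beyond the scatter). The groups differ only in one ring atom, sulfur for oxygen, whereas the earlier step on this carbon exchanged two very different groups and could not show that so small a change matters this much here. Compound 4 gives a limit and not a number, so the step sets only a minimum size, and compound 4 joins compound 1 at the same ceiling: the limit of > 20000 nM in this assay, at which 2 of the 4 values shown sit.

Still open, going by these compounds, is whether furan-3-yl is alone in holding activity on this carbon, or whether a pyridin-3-yl ring or an aminomethyl group would also do so. The part played by methylthio in place of methoxy also cannot be read, as compound 3 differs from compound 1 and compound 2 in two places.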